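Aryl versus benzyl on the piperazine nitrogen

This account rests on a few compounds, and the source may have more. Where it says the series, first, only, none or still open, it means among the compounds named here.

Measured compounds:
compound 1 `CCCn1c(=O)[nH]c2nc(-c3ccc(S(=O)(=O)N4CCN(C)CC4)cc3)[nH]c2c1=O`: 48.2 nM
compound 2 `CCCn1c(=O)[nH]c2nc(-c3ccc(S(=O)(=O)N4CCN(Cc5ccc(Br)cc5)CC4)cc3)[nH]c2c1=O`: 0.153 nM

In an assay on CHO cells for displacement of a labelled ligand from adenosine receptor A2b (Homo sapiens), read by scintillation counting, with a stated time of 75 min, in the presence of a further agent that is not named here (a lower number here means a stronger inhibitor, a higher number a weaker inhibitor), compound 1 gives 48.2 nM and compound 2 gives 0.153 nM. Among the measured compounds shown here, compound 2 holds the lowest number of the two, with compound 1 as its only neighbour; the step of a 320-fold lower number from compound 1 to compound 2 (2.50 log units; beyond the scatter) is large and beyond the scatter. Compound 3 `CCCn1c(=O)[nH]c2nc(-c3ccc(S(=O)(=O)N4CCN(c5ccccc5Cl)CC4)cc3)[nH]c2c1=O` differs from compound 2 by 2-chlorophenyl in place of 4-bromobenzyl on an amine nitrogen in a ring. For the measured compounds named here, only the step of a 320-fold lower number from compound 1 to compound 2 (2.50 log units; beyond the scatter) bears on this change, and it shows how much a substituted aromatic group on that ring nitrogen can add over hydrogen. Going by the values given here, compound 3 keeps an aromatic ring there but loses the saturated chain carbon of the benzyl group, and no measured pair speaks to that difference. The expectation is a modest rise in this assay, a 13-fold higher number from compound 2 to compound 3 (1.12 log units; beyond the scatter), with compound 3 estimated at 2 nM, ranging from 0.3 nM to 15 nM.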

Compound 3, inhibition constant: 0.403 nM
Estimate against measurement, compound 3: 5.0-fold (0.70 log units) above, within the range that was stated.
By their numbers in this assay, from the lowest: compound 2; then compound 3; then compound 1.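

In this assay, an aromatic ring bound directly to the ring nitrogen keeps most of the gain over the methyl group, with a 120-fold lower number from compound 1 to compound 3 (2.08 log units; beyond the scatter), so the large gain seen earlier does not depend on a saturated chain carbon at this position. The exchange of 4-bromobenzyl for 2-chlorophenyl still costs something, with a 2.6-fold higher number from compound 2 to compound 3 (0.42 log units; beyond the scatter), but this single step changes the chain carbon, the halogen and the halogen's place on the ring all at once. No measured evidence gives a reason for either step.

From the compounds shown here alone, how much of that modest rise belongs to each of those three changes remains open. A 2-chlorobenzyl group or an unsubstituted phenyl group on the same nitrogen would begin to separate them, and a longer phenylethyl chain would test the other direction.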